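A few compounds are considered here, and "the series" means these few. Any claim that something is new, unique, unknown or untested is made for them only; others in the source may bear on it.

Of the compounds shown here, three have been tested so far in an ADME assay on RAW264.7 cells (Mus musculus) for cytotoxicity, read by MTT assay, with a stated time of 48 h; a lower number here means a stronger inhibitor, a higher number a weaker inhibitor. Compound 1, `Cc1cc(NC(=O)c2ccc(Cl)cc2)ccc1NS(C)(=O)=O`, gives 69100 nM. Compound 2, `Cc1cc(NC(=O)c2ccc(C#N)cc2)ccc1NS(C)(=O)=O`, gives 171000 nM in this assay. These two differ in only one place, (cyano in place of chloro on an aromatic carbon), and that single change made a 2.5-fold higher number from compound 1 to compound 2 (0.39 log units; beyond the scatter).

Compound 3, `CCS(=O)(=O)Nc1ccc(NC(=O)c2ccc(Cl)cc2)cc1OC`, gives 60100 nM in this assay. Its number is the lowest of the three, yet it lies so close to that of compound 1 that the two fall within the usual scatter, and no order between them can be read from the values. Against compound 2 the gap is wider and does lie beyond the scatter. The difference between the core of compound 3 and the core of compound 1 is not broken down here.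

Compound 4, `CCS(=O)(=O)Nc1ccc(NC(=O)c2ccc(C#N)cc2)cc1OC`, has not yet been measured. It stands to compound 3 as compound 2 stands to compound 1: cyano in place of chloro on an aromatic carbon. The place of the change is the same in both pairs, so this is the same change made a second time, on the other core. Because the earlier instance gave a 2.5-fold higher number from compound 1 to compound 2 (0.39 log units; beyond the scatter), compound 4 is expected to give about 150000 nM in this assay. Most repeat measurements of compound 4 would be expected to fall between 75000 nM and 300000 nM. This estimate means an expected 2.5-fold higher number from compound 3 to compound 4 (0.40 log units; beyond the scatter), resting on that one earlier step alone.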

Compound 4, half-maximal inhibitory concentration: 66400 nM
Beside the measured number, compound 4's estimate is 2.3-fold (0.35 log units) above it; the measured number lies below the stated range.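

In this assay, going by these compounds alone, putting cyano in place of chloro on the second core gave a 1.1-fold higher number from compound 3 to compound 4 (0.04 log units; within the scatter), so on this core the change leaves no difference that can be read, although the same change on the first core gave a step beyond the scatter. Set side by side, the two steps still cannot be told apart, since the gap between them is no larger than the scatter of two such steps allows: the same change on two cores in this assay, a 2.5-fold higher number (0.39 log units; beyond the scatter) from compound 1 to compound 2 and a 1.1-fold higher number (0.04 log units; within the scatter) from compound 3 to compound 4, 2.2-fold (0.35 log units) apart, within the scatter of two such steps. This does not show that the change carries over from one core to the other at the same size, and it does not show that the core alters its effect either, as two pairs are too few to decide between these readings, and they give no reason why the two steps look different in size.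

The compounds shown leave open what other groups would do in the same place on the aromatic ring, such as bromo, an amine or a carboxylic acid. Also open, on these data alone, is how the step from chloro to cyano would turn out on a third core, for example one with a longer chain on the sulfonamide.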